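A few compounds are considered here, and "the series" means these few. Any claim that something is new, unique, unknown or untested is made for them only; others in the source may bear on it.

Of the compounds shown here, three that share one core have been tested in a functional assay on A549 cells (Homo sapiens) for cytotoxicity, read by colorimetric assay and MTT assay, with a stated time of 3 days, tested at 1 uM; a lower number here means a stronger effect, a higher number a weaker effect of the compound at the concentration tested. Compound 1 `O=C1COc2ccc(-c3nn(-c4ccc(Br)cc4)cc3-c3ccccc3)cc2N1` gives 81.5%. Compound 2 `COc1ccc(-n2cc(-c3ccccc3)c(-c3ccc4c(c3)NC(=O)CO4)n2)cc1` gives 95.6%, and compound 3 `O=C1COc2ccc(-c3nn(-c4cc(Cl)cc(Cl)c4)cc3-c3ccccc3)cc2N1` gives 93.1%. Compound 3 thus holds the second highest of the three numbers: its nearest neighbour is compound 2, and the step of a number 2.5 percentage points lower from compound 2 to compound 3 (within the scatter) lies within the scatter, whereas the step of a number 11.6 percentage points higher from compound 1 to compound 3 (beyond the scatter) lies beyond it.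

Compound 4 `O=C1COc2ccc(-c3nn(-c4ccccc4)cc3-c3ccccc3)cc2N1` is the next compound to be measured in this assay. It differs from compound 3 in one place: phenyl in place of 3,5-dichlorophenyl on an aromatic nitrogen. Among the compounds with values here, two measured steps alter the same group on the aromatic nitrogen, namely a number 11.6 percentage points higher from compound 1 to compound 3 (beyond the scatter) and a number 2.5 percentage points lower from compound 2 to compound 3 (within the scatter), and the step of a number 14.1 percentage points higher from compound 1 to compound 2 (beyond the scatter) also changes only that group. All three measured numbers sit in a narrow band near the top of the scale, so exchanging the group on the aromatic nitrogen has so far shifted this assay only modestly. A plain phenyl is expected to keep compound 4 in the same band, with a step of a number 3.1 percentage points lower from compound 3 to compound 4 (within the scatter) that is expected to remain within the scatter. Compound 4 is therefore estimated at 90%, with a range from 78% to 100%.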

Compound 4, a percentage reported as activity, at one concentration (the size of the read-out at that concentration, not a potency): 92.2%
The estimate for compound 4 lay 2.2 percentage points below the measured number, within the range that was stated.
By their numbers in this assay, from the lowest: compound 1; then compounds 4, 3 and 2 (each within the scatter of the next).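

Taking both chlorines off the ring on the aromatic nitrogen makes no readable difference in this assay: the change is a number 0.9 percentage points lower from compound 3 to compound 4 (within the scatter) and so cannot be told from repeat measurement. Removing the methoxy gives the same picture, with a number 3.4 percentage points lower from compound 2 to compound 4 (within the scatter), so the bare phenyl now serves as a reference, and neither the 3,5-dichlorophenyl nor the 4-methoxyphenyl group separates from it. Within the data shown here, removing the bromo is different, with a number 10.7 percentage points higher from compound 1 to compound 4 (beyond the scatter), which shows that compound 1 is the one compound of the four that stands apart, and that this comes with the bromo rather than with the shared core, although the step is only modest and all four numbers remain high on the scale.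

As far as these compounds go, an amine or a carboxylic acid on this phenyl ring could show whether this position can move the number further, and it remains open whether a lone chloro would behave like the bromo. No measurement shown here gives a reason for the separate position of compound 1.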